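Replacing hexylamino with hydroxy on the carbonyl of compound 1

The source may hold more compounds than are shown below. What is called first, only, known or untested is meant among the compounds shown, and "the series" means these compounds.

Compound 1 (`CCCCCCNC(=O)c1cc(C#Cc2cc(OC)ccc2OC)ccc1OC`) gives > 100000 nM in a functional assay on DU-145 cells (Homo sapiens) for antiproliferative activity (a higher number here means a weaker inhibitor of growth, a lower number a stronger inhibitor of growth), as a limit of the assay and not a number. Compound 1 therefore stands at the limit of > 100000 nM in this assay, at which 1 of the 2 values shown sits, and offers no exact starting point. Within the data shown here, compound 2 (`COC(=O)c1cc(/C=C\c2cc(OC)ccc2OC)ccc1OC`) gives 18100 nM in this assay and is the only numbered reading so far. Among the measured compounds shown here, no two measured compounds differ in just one place, so no measured step guides the change ahead. Compound 3 (`COc1ccc(OC)c(C#Cc2ccc(OC)c(C(=O)O)c2)c1`) keeps the core of compound 1 and takes the change hydroxy in place of hexylamino on a carbonyl carbon. A modest gain in growth inhibition is expected at best, and a second limit reading would be no surprise. The estimate amounts to an at least 2.2-fold lower number from compound 1 to compound 3 (0.34 log units; beyond the scatter) as an expected step and no more. Compound 3 is expected at 45000 nM in a range from 12000 nM to 100000 nM on this estimate.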

Compound 3, concentration for 50% growth inhibition: 26900 nM
Compound 3: the middle estimate sits 1.7-fold (0.22 log units) above what was measured; low and high end bracket the measured number.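

Among these compounds, replacing hexylamino with hydroxy on the carbonyl carbon gives the first measured step at this position in this assay: an at least 3.7-fold lower number from compound 1 to compound 3 (0.57 log units; beyond the scatter). With the rest of the core of compound 1 unchanged, compound 3 gives 26900 nM, so this change moves the series to a numbered reading, although that reading remains in the high micromolar range. Compound 1 gives a limit of the assay and not a number, so the true size of the step remains unknown because only its lower bound can be read: the limit of > 100000 nM in this assay, at which 1 of the 3 values shown sits.

The compounds shown do not separate the effect of removing hexylamino from that of introducing hydroxy. A primary amide, a shorter chain such as methylamino, or a methyl ester on the same core would help to separate them.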